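Notes on amide-end variation in the diaryl thioether series

This account rests on a few compounds, and the source may have more. Where it says the series, first, only, none or still open, it means among the compounds named here.

Measured compounds:
compound 1, `O=C(c1ccccc1)N1CCC(NCCSC(c2ccc(F)cc2)c2ccc(F)cc2)CC1`: 100%
compound 2, `O=C(c1ccc(F)cc1)N1CCC(NCC[S+]([O-])C(c2ccc(F)cc2)c2ccc(F)cc2)CC1`: 100%

In an ADME assay on microsomes from liver (Rattus norvegicus) for metabolic stability, read by LC-MS, using NADPH, tested at 10 uM (a lower number here means that less of the compound is left, a higher number that more of the compound is left), compound 1 gives 100%. Compound 2 gives 100% in this assay; compound 1 stands level with compound 2 at the digits shown, within the scatter, so the two values show no difference between them. Going by the values given here, no step between measured compounds that differ in one place exists in this set, so nothing measured tells how a change at the amide end moves this read-out.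

Compound 3, `O=C(c1ccc(F)cc1F)N1CCC(NCCSC(c2ccc(F)cc2)c2ccc(F)cc2)CC1`, is not yet measured in this assay. It differs from compound 1 by 2,4-difluorophenyl in place of phenyl on a carbonyl carbon. Among the compounds with values here, both measured compounds sit at full recovery in this assay, and with no single-point step available the expectation is no move beyond the scatter; a drop cannot be ruled out, but nothing measured supports one. The expected step is a number 4 percentage points lower from compound 1 to compound 3 (within the scatter). For compound 3 the estimate in this assay is 96%, with a range from 85% to 100%.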

Compound 3, percent of the compound remaining: 100%
Compound 3: the middle estimate sits 4 percentage points below what was measured, and the stated range covers the measured number.
By their numbers in this assay, from the lowest: compounds 1, 2 and 3 (each within the scatter of the next).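

In this assay, 2,4-difluorophenyl in place of phenyl on a carbonyl carbon gives no change at the digits printed from compound 1 to compound 3 (within the scatter), and this is the only single-place step at the amide end in the compounds shown. It shows that, with the thioether retained, the read-out does not separate the benzoyl from the (2,4-difluorophenyl)carbonyl group, although compound 3 and compound 1 both sit at the top of the scale, where a further rise could not register. Nothing available accounts for this flat result or links it to any property of the two fluorine atoms.

On these data alone, the position has been probed only with these aryl groups, so it remains open whether a carboxylic acid, an amine or a longer chain in place of phenyl on the same carbonyl carbon would leave less of the compound remaining. As far as these compounds go, compound 2 differs from compound 1 and from compound 3 in more than one place, so the separate contribution of the sulfoxide also remains open.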